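The source may report more compounds than this note shows. Statements on the series, on what has been measured and on what is new or still open speak of the compounds shown alone.

In a functional assay on NIH3T3 cells (Mus musculus) for inhibition, read by MTT assay, with a stated time of 72 h (on this read-out lower numbers stand for stronger inhibition and higher numbers for weaker inhibition), compound 1 `C=C1CC[C@H]2[C@@](C)(CC[C@@H](O)[C@@]2(C)C(=O)OC)[C@@H]1/C=C/C1=CCOC1=O` gives 111000 nM, and compound 2 `C=C1CC[C@H]2[C@@](C)(CC[C@@H](O)[C@@]2(C)C(=O)OCc2ccccn2)[C@@H]1/C=C/C1=CCOC1=O` gives 80200 nM. Among the compounds with values here, on these numbers the two cannot be told apart: the only measured step, a 1.4-fold lower number from compound 1 to compound 2 (0.14 log units; within the scatter), puts pyridin-2-yl in place of hydrogen on a saturated chain carbon bound to an oxygen next to a carbonyl group. Compound 3 `C=C1CC[C@H]2[C@@](C)(CC[C@@H](O)[C@@]2(C)C(=O)OC)[C@@H]1C/C=C1\C=COC1=O` has the same atoms as compound 1, joined differently: a group of 8 heavy atoms (6 carbon, 2 oxygen; one five-membered non-aromatic ring with 1 hetero atom) in place of a group of 8 heavy atoms (6 carbon, 2 oxygen; one five-membered non-aromatic ring with 1 hetero atom), on a saturated ring carbon. The change lies on a saturated ring carbon of a six-membered non-aromatic ring of carbon only. Within the data shown here, no measured compound tests this change, so the one known step offers only an indirect guide, and no shift beyond the scatter in this assay can be argued in either direction. The estimated step is a 1.1-fold lower number from compound 1 to compound 3 (0.05 log units; within the scatter). Compound 3 is expected at 100000 nM, with an estimated range of 35000 nM to 250000 nM.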

Compound 3, half-maximal inhibitory concentration: 177000 nM
Compound 3: middle estimate off by 1.8-fold (0.25 log units), on the low side; measured number inside the range.
By their numbers in this assay, from the lowest: compounds 2, 1 and 3 (each within the scatter of the next, the first and the last beyond it).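

In this assay the step is a 1.6-fold higher number from compound 1 to compound 3 (0.20 log units; within the scatter), so joining the same atoms differently in the group on this saturated ring carbon gives a number that cannot be told apart from that of compound 1. Within the data shown here, this is the first view of this place, on a six-membered non-aromatic ring of carbon only, since the earlier step concerned a saturated chain carbon bound to an oxygen next to a carbonyl group, and neither change has moved the number beyond the scatter. No other data bear on this result.

As far as these compounds go, what a group of different atoms, such as an amine or a carboxylic acid, would do on this saturated ring carbon stays open. Also open, from the compounds shown here alone, is whether the group of compound 3 would give a similar number alongside the pyridin-2-yl of compound 2.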